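Chain-linked piperazine in place of piperidin-4-yl on the core

This account rests on a few compounds, and the source may have more. Where it says the series, first, only, none or still open, it means among the compounds named here.

Compound 2 `c1ccc2c(c1)CN[C@@H](CN(CC1CCNCC1)[C@H]1CCCc3cccnc31)C2` gives 86% in an ADME assay on microsomes from liver (Homo sapiens) for metabolic stability, read by LC-MS, with a stated time of 10 min, tested at 0.5 uM (a higher number here means that more of the compound is left, a lower number that less of the compound is left), the highest of the three numbers in hand. Compound 1 `CN1CCN(CCCN(C[C@H]2Cc3ccccc3CN2)[C@H]2CCCc3cccnc32)CC1` gives 72%, and compound 3 `c1cnc2c(c1)CCC[C@@H]2N(CCCN1CCNCC1)Cc1nc2ccccc2s1` gives 50%. Compound 4 `c1ccc2c(c1)CN[C@@H](CN(CCCCN1CCNCC1)[C@H]1CCCc3cccnc31)C2` differs from compound 2 by 3-(piperazin-1-yl)propyl in place of piperidin-4-yl on a saturated chain carbon bound to an amine nitrogen. Within the data shown here, the one step that bears on it is a number 14 percentage points higher from compound 1 to compound 2 (beyond the scatter), which runs the other way: compound 1 carries a chain ending in a methylated piperazine, and compound 4 returns to a piperazine on a chain, one carbon longer and without the methyl. A step of similar size, in the downward direction, is therefore expected, a number 12 percentage points lower from compound 2 to compound 4 (beyond the scatter). Compound 4 is accordingly expected to give about 74% in this assay, within a range of 60% to 88%.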

Compound 4, percent of the compound remaining: 82%
For compound 4 the middle estimate is 8 percentage points below the measured one; the range from low to high includes it.
By their numbers in this assay, from the lowest: compound 3; then compounds 1, 4 and 2 (each within the scatter of the next, the first and the last beyond it).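

In this assay, the change on a saturated chain carbon bound to an amine nitrogen gives a number 4 percentage points lower from compound 2 to compound 4 (within the scatter), so the ring on a chain, 3-(piperazin-1-yl)propyl, reads the same as piperidin-4-yl at this position. Compounds with a piperazine on a chain are also not set apart by the other change, with a number 10 percentage points higher from compound 1 to compound 4 (within the scatter), where (piperazin-1-yl)methyl stands in place of 4-methylpiperazin-1-yl. Nothing in hand gives a reason for these readings.

That last step does not separate the lost methyl from the longer chain. On these data alone, whether a carboxylic acid or a longer chain in this place would hold the same level stays open.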